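This account rests on a few compounds, and the source may have more. Where it says the series, first, only, none or still open, it means among the compounds named here.

Of the compounds shown here, three have so far been measured in an assay on HEK293 cells for binding affinity to 5-hydroxytryptamine receptor 7 (Homo sapiens), read by radioligand binding, tested at 1 uM; on this read-out higher numbers stand for more inhibition at the one concentration tested (going by the name of the read-out) and lower numbers for less inhibition. Compound 1 `Brc1ccc2ccn(CCN3CCN(C4CCCCC4)CC3)c2c1` gives 36%, compound 2 `CN1CCCN(CCn2ccc3c(Br)cccc32)CC1` gives 33%, and compound 3 `CN1CCCN(CCn2ccc3ccc(O)cc32)CC1` gives 28%. Compound 3 thus carries the lowest of the three numbers, but its gap to compound 2 and its gap to compound 1 both lie within the usual scatter of repeated measurements, so on these data the three compounds cannot be told apart. Going by the values given here, no two of the measured compounds differ in only one place, so no single structural step has yet been tied to a shift in the read-out.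

Compound 4 `Cc1ccc2ccn(CCN3CCCN(C)CC3)c2c1` is not yet measured. It differs from compound 3 in one place: methyl in place of hydroxy on an aromatic carbon. Among the compounds with values here, nothing among the measured compounds shows what this exchange does, so the expected step of a number 4 percentage points higher from compound 3 to compound 4 (within the scatter) is none beyond the scatter, and the uncertainty is wide. Compound 4 is therefore expected to give roughly 32%, with a range from 12% to 55%.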

Compound 4, a percentage reported as inhibition, at one concentration (the size of the read-out at that concentration, not a potency): 62%
For compound 4 the middle estimate is 30 percentage points below the measured one; the measured number lies above the stated range.
By their numbers in this assay, from the lowest: compounds 3, 2 and 1 (each within the scatter of the next); then compound 4.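

In this assay, going by these compounds alone, putting methyl in place of hydroxy on this aromatic carbon gives a number 34 percentage points higher from compound 3 to compound 4 (beyond the scatter), the first step that can be tied to a single structural change. It shows that this place on the six-membered aromatic ring matters for the read-out: exchanging one heavy atom, with the rest of the structure unchanged, is enough to produce a step beyond the scatter. The data available give no explanation for why this exchange has such an effect.

On these data alone, whether a methoxy group, a chlorine atom or a plain hydrogen on this carbon would read more like methyl or like hydroxy remains open, so the step cannot yet be assigned to gaining methyl rather than losing hydroxy. Also open, as far as these compounds go, is whether the same exchange would have a similar effect with the side chain of compound 1.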